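The source may report more compounds than this note shows. Statements on the series, on what has been measured and on what is new or still open speak of the compounds shown alone.

In a functional assay on A549 cells (Homo sapiens), read by MTT assay, with a stated time of 72 h (on this read-out lower numbers stand for stronger inhibition and higher numbers for weaker inhibition), compound 1 `COc1ncnc2c1c(-c1cccs1)cn2[C@@H]1O[C@H](CO)[C@@H](O)[C@H]1O` gives 4850 nM. Compound 2 `COc1ncnc2c1c(-c1ccccc1)cn2[C@@H]1O[C@H](CO)[C@@H](O)[C@H]1O` reaches only a limit in this assay, > 20000 nM. Compound 3 `CNc1ncnc2c1c(-c1ccccc1)cn2[C@@H]1O[C@H](CO)[C@@H](O)[C@H]1O` likewise reaches only a limit, > 20000 nM. Both sit at the limit of > 20000 nM in this assay, at which 2 of the 3 values shown sit. The change thiophen-2-yl in place of phenyl on an aromatic carbon produced an at least 4.1-fold lower number from compound 2 to compound 1 (0.61 log units; beyond the scatter). The change methylamino in place of methoxy on an aromatic carbon produced a step that the two limits leave unreadable from compound 2 to compound 3. Compound 4 `CNc1ncnc2c1c(-c1cccs1)cn2[C@@H]1O[C@H](CO)[C@@H](O)[C@H]1O` has not yet been measured; it differs from compound 3 by thiophen-2-yl in place of phenyl on an aromatic carbon, the same change as that from compound 2 to compound 1, at an identical place. The step expected is an at least 2.8-fold lower number from compound 3 to compound 4 (0.45 log units; beyond the scatter), since the same change gave an at least 4.1-fold lower number from compound 2 to compound 1 (0.61 log units; beyond the scatter). With compound 3 known only as a limit, the starting point is uncertain, so the expectation is loose. Compound 4 is estimated to give 7000 nM, expected between 2500 nM and 20000 nM.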

Compound 4, half-maximal inhibitory concentration: > 20000 nM
Compound 4 gave a limit, no number (the forecaster's own chance of this, stated with the estimate: 30%); at least 2.8-fold (0.45 log units) between middle value and limit.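

Compound 4 stays at a limit in this assay, > 20000 nM, so the lower number that thiophen-2-yl brought to the methoxy compounds did not appear as a measurable value in the methylamino compounds. With thiophen-2-yl kept in place, methylamino in place of methoxy produced an at least 4.1-fold higher number from compound 1 to compound 4 (0.61 log units; beyond the scatter), so the result of compound 1 does not carry over to the methylamino core. The steps that join two limits cannot be read, so it remains unknown whether thiophen-2-yl lowers the number at all with methylamino present, and the transfer is neither confirmed nor ruled out: the limit of > 20000 nM in this assay, at which 3 of the 4 values shown sit.

The compounds shown leave open how an unsubstituted amino group or a dimethylamino group would behave in place of methoxy. They also leave open whether furan-2-yl could stand in for thiophen-2-yl on the methoxy core.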